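Swapping the Pyrimidine for an Indazole on the Sulfonamide

The compounds below may be only part of what the source reports. "The series", "measured", "known", "first", "only" and "open" are said of these compounds alone.

Compound 1 `NS(=O)(=O)c1ccc(N/C=C\C(=O)c2cc3ccccc3oc2=O)cc1` carries a plain sulfonamide on the shared core. In a functional assay on T47D cells (Homo sapiens) for cytotoxicity, read by sulforhodamine B assay, with a stated time of 48 h (on this read-out lower numbers stand for stronger inhibition and higher numbers for weaker inhibition), compound 1 gives 109000 nM. Compound 2 `Cc1ccnc(NS(=O)(=O)c2ccc(N/C=C\C(=O)c3cc4ccccc4oc3=O)cc2)n1`, which places a 4-methylpyrimidin-2-yl group on the sulfonamide nitrogen, gives 24500 nM in this assay, and compound 3 `COc1cnc(NS(=O)(=O)c2ccc(N/C=C\C(=O)c3cc4ccccc4oc3=O)cc2)nc1`, with a 5-methoxypyrimidin-2-yl group in the same place, gives 8800 nM. Compound 3 thus stands lowest of the three numbers: the step of a 12-fold lower number from compound 1 to compound 3 (1.09 log units; beyond the scatter) is large, and the step of a 2.8-fold lower number from compound 2 to compound 3 (0.44 log units; beyond the scatter) is modest, as is the step of a 4.4-fold lower number from compound 1 to compound 2 (0.65 log units; beyond the scatter).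

Compound 4 `O=C(/C=C\Nc1ccc(S(=O)(=O)Nc2ccc3cn[nH]c3c2)cc1)c1cc2ccccc2oc1=O` differs from compound 3 in one place: 1H-indazol-6-yl in place of 5-methoxypyrimidin-2-yl on a sulfonamide nitrogen. All three measured steps concern this same nitrogen, and each of them shows that an aromatic ring there goes with a lower number than hydrogen. Among the compounds with values here, no measured step, however, compares a two-ring system with a single pyrimidine, so the size of this particular change is unknown. Because the step of a 12-fold lower number from compound 1 to compound 3 (1.09 log units; beyond the scatter) shows that an aromatic group on this nitrogen matters most, compound 4 is expected to stay near compound 3, with the step of a 1.3-fold lower number from compound 3 to compound 4 (0.10 log units; within the scatter) estimated to fall within the scatter. Compound 4 is therefore expected to give about 7000 nM in this assay, within a range from 1800 nM to 28000 nM.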

Compound 4, half-maximal inhibitory concentration: 96500 nM
Compound 4: middle estimate off by 14-fold (1.14 log units), on the low side; measured number above the stated range.
By their numbers in this assay, from the lowest: compound 3; then compound 2; then compounds 4 and 1 (each within the scatter of the next).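

The result removes the simple reading that any aromatic ring on the sulfonamide nitrogen goes with a lower number in this assay: with 1H-indazol-6-yl in place of hydrogen, the comparison reads a 1.1-fold lower number from compound 1 to compound 4 (0.05 log units; within the scatter). The identity of the group therefore matters, since the step of an 11-fold higher number from compound 3 to compound 4 (1.04 log units; beyond the scatter) is large and the step of a 3.9-fold higher number from compound 2 to compound 4 (0.60 log units; beyond the scatter) is modest, so among these compounds both pyrimidine groups go with lower numbers than the indazole. The change alters several counted features at once, including the ring make-up and the hydrogen-bond donors and acceptors, and no supporting measurement is available to say which of them, if any, accounts for the gap.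

These compounds cannot separate the effect of having two fused rings from that of the indazole's hydrogen-bond donor, a question that 1-methyl-1H-indazol-6-yl on the same nitrogen would address directly. From the compounds shown here alone, it also remains open whether a single ring with fewer ring nitrogens, such as phenyl or pyridin-2-yl, would fall nearer compound 3 or nearer compound 4.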